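Branching the Ester Side Chain of a Shared Lactone Core

The source may hold more compounds than are shown below. What is called first, only, known or untested is meant among the compounds shown, and "the series" means these compounds.

The measured compounds:
compound 1, `CC(C)C(=O)O[C@H]1C[C@@H](C)C=C2C=C[C@H](C)[C@H](CC[C@@H]3C[C@@H](O)CC(=O)O3)C21`, gives 7.7 nM in an assay for inhibition of 3-hydroxy-3-methylglutaryl-coenzyme A reductase (Rattus norvegicus); a higher number here means a weaker inhibitor, a lower number a stronger inhibitor;
compound 2, `CC(=O)O[C@H]1C[C@@H](C)C=C2C=C[C@H](C)[C@H](CC[C@@H]3C[C@@H](O)CC(=O)O3)C21`, gives 269 nM in this assay;
compound 3, `CC(C)CC(=O)O[C@H]1C[C@@H](C)C=C2C=C[C@H](C)[C@H](CC[C@@H]3C[C@@H](O)CC(=O)O3)C21`, gives 5.4 nM in this assay.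

All three share the same core and differ only in the ester on its oxygen. Compound 2, the acetate, stands highest of the three numbers, which here means the weakest inhibitor. Replacing its methyl with isopropyl gives a 35-fold higher number from compound 1 to compound 2 (1.54 log units; beyond the scatter) read backwards, and adding an isopropyl on the chain carbon bound to the carbonyl gives a 50-fold lower number from compound 2 to compound 3 (1.70 log units; beyond the scatter). Between compound 1 and compound 3 the change is only a 1.4-fold lower number from compound 1 to compound 3 (0.15 log units; within the scatter).

Compound 4, `CC(CC(=O)O[C@H]1C[C@@H](C)C=C2C=C[C@H](C)[C@H](CC[C@@H]3C[C@@H](O)CC(=O)O3)C21)C(F)(F)F`, is not yet measured. It differs from compound 2 by 1-(trifluoromethyl)ethyl in place of hydrogen on a saturated chain carbon bound to a carbonyl carbon. This is the same kind of enlargement of the acyl chain that separates compound 2 from compound 3, with one methyl of the isobutyl replaced by trifluoromethyl. The two large steps away from compound 2 therefore suggest a large step down in this assay for compound 4 as well, expected to be about a 34-fold lower number from compound 2 to compound 4 (1.53 log units; beyond the scatter). Compound 4 is estimated at 8 nM, with a range from 3 nM to 25 nM.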

Compound 4, half-maximal inhibitory concentration: 3.5 nM
Compound 4: the middle estimate sits 2.3-fold (0.36 log units) above what was measured; the range from low to high includes it.
By their numbers in this assay, from the lowest: compounds 4, 3 and 1 (each within the scatter of the next, the first and the last beyond it); then compound 2.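

Putting a trifluoromethyl in place of one methyl of the branched chain leaves the number in this assay unchanged within the scatter, with a 1.5-fold lower number from compound 3 to compound 4 (0.19 log units; within the scatter) as the step, so this position accepts that swap without a measurable loss. The full enlargement from the acetate, 1-(trifluoromethyl)ethyl in place of hydrogen, gives a 77-fold lower number from compound 2 to compound 4 (1.89 log units; beyond the scatter) as its step and is the largest seen so far on this chain carbon, and a 2.2-fold lower number from compound 1 to compound 4 (0.34 log units; beyond the scatter) marks the first modest separation from the isopropyl ester, which compound 3 did not reach. No measurement offered here explains what the fluorinated chain does at this position.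

The compounds shown stop at short alkyl and fluoroalkyl esters, so it stays open whether a longer chain such as hexyl, a phenyl ring or an amine on the acyl chain would keep numbers this low. The carbon carrying the trifluoromethyl in compound 4 is also drawn without a defined arrangement, which leaves open whether its two mirror-image forms would read alike.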